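The source may report more compounds than this note shows. Statements on the series, on what has been measured and on what is new or still open speak of the compounds shown alone.

Of the compounds shown here, three have been measured in an assay on CHO-K1 cells for displacement of a labelled ligand from melanin-concentrating hormone receptor 1 (Homo sapiens), read by scintillation counting; a higher number here means a weaker inhibitor, a lower number a stronger inhibitor. Compound 1 `CC(C)N(C)c1nc2ccc(NC(=O)c3cnc(-c4ccc(F)cc4)cn3)cc2[nH]1` gives 2.7 nM in this assay, compound 2 `CN(c1nc2ccc(NC(=O)CCc3ccc(C(F)(F)F)cc3)cc2[nH]1)C1CC1` gives 24 nM, and compound 3 `CC(C)N(C)c1ccc2nc(NC(=O)CCc3ccc(C(F)(F)F)cc3)ccc2n1` gives 375 nM. Among these three numbers compound 2 stands second highest: compound 1 lies at a lower number than compound 2 by a gap beyond the scatter, and compound 3 lies at a higher number than compound 2, also by a gap beyond the scatter. No two of the measured compounds differ in one place only, so none of these gaps can be tied to a single structural change.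

Compound 4 `CC(C)N(C)c1nc2ccc(NC(=O)CCc3ccc(C(F)(F)F)cc3)cc2[nH]1` has not yet been measured. It differs from compound 2 in one place: isopropyl in place of cyclopropyl on a nitrogen on an aromatic ring. Compound 1 also carries isopropyl(methyl)amino, but it differs from compound 4 elsewhere in the molecule, and compound 3 has a different core, so neither gives a direct reading of this change.

Swapping cyclopropyl for isopropyl on this nitrogen is a small change, and compound 4 is expected to stay close to compound 2, with a step from compound 2 to compound 4 of a 1.1-fold lower number from compound 2 to compound 4 (0.04 log units; within the scatter), not beyond the scatter in either direction. Compound 4 is therefore estimated at 22 nM in this assay, within a range from 8 nM to 65 nM.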

Compound 4, half-maximal inhibitory concentration: 5.9 nM
For compound 4 the middle estimate is 3.7-fold (0.57 log units) above the measured one; measured number below the stated range.
By their numbers in this assay, from the lowest: compound 1; then compound 4; then compound 2; then compound 3.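

In this assay, going by these compounds alone, replacing cyclopropyl(methyl)amino with isopropyl(methyl)amino gives a 4.1-fold lower number from compound 2 to compound 4 (0.61 log units; beyond the scatter), the first step in this set that can be tied to a single structural change. It shows that this place on a nitrogen on an aromatic ring responds beyond the scatter even to an exchange between two groups that each have 3 carbon atoms and no hydrogen-bond donors or acceptors, the counted difference being that the three-membered ring of cyclopropyl leaves and isopropyl has no ring. No measurement available here accounts for the step, so its cause remains unassigned.

As far as these compounds go, whether the same exchange would carry the same size of step with the amide side of compound 1 or on the core of compound 3 remains open, as neither compound has a partner that differs from it only at this group. Also open, from the compounds shown here alone, is how far the trend extends along a wider range of groups on this nitrogen, such as ethyl, tert-butyl or cyclobutyl, and whether any of them would give a lower number than isopropyl does in compound 4.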